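The source may report more compounds than this note shows. Statements on the series, on what has been measured and on what is new or still open speak of the compounds shown alone.

Series notes, cytotoxicity arm. Compound 2 `O=C(NCCNS(=O)(=O)c1ccc(-c2ccccc2Oc2ccc([N+](=O)[O-])c([N+](=O)[O-])c2)s1)Nc1ccc(Cl)cc1` is one of the two ureas that reach the limit in an ADME assay on HEK-293T cells (Homo sapiens) for cytotoxicity, read by CCK-8 assay, with a stated time of 48 h; a higher number here means a weaker inhibitor, a lower number a stronger inhibitor; in this assay compound 2 gives > 20000 nM, which is a limit of the assay and not a number. Compound 1 `Nc1ccc(Oc2ccccc2-c2ccc(S(=O)(=O)NCCNC(=O)Nc3ccc(Cl)cc3)s2)cc1` in this assay gives > 20000 nM, again a limit. Going by the values given here, the only single-point step recorded, a step that the two limits leave unreadable from compound 1 to compound 2, is therefore unreadable in size, with the limit of > 20000 nM in this assay, at which 2 of the 3 values shown sit, setting where both ends sit. Among the compounds with values here, the one compound with a number, compound 3 `COc1ccc(Oc2ccc(C(C)C)cc2-c2ccsc2S(=O)(=O)NCCNC(=O)Nc2cc(C(F)(F)F)cc(C(F)(F)F)c2)cc1OC`, gives 12100 nM in this assay, a different core and a different aryl urea, so no single-point step links it to compound 2.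

Compound 4 `COc1cccc(NC(=O)NCCNS(=O)(=O)c2ccc(-c3ccccc3Oc3ccc([N+](=O)[O-])c([N+](=O)[O-])c3)s2)c1` is the next member. Its difference from compound 2 is 3-methoxyphenyl in place of 4-chlorophenyl on an amide-type nitrogen, at the urea end of the molecule. Within the data shown here, no measured step in this assay touches that end; the one recorded step lies on the diaryl ether side and is unreadable anyway. The expectation for compound 4 is thus that it stays where compound 2 stands, with the step of a number no higher from compound 2 to compound 4 (the limit leaves the size open) expected to lie within the scatter. Compound 4 is estimated at 20000 nM in this assay, within 8000 nM to 50000 nM, most likely reported only as a limit.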

Compound 4, half-maximal inhibitory concentration: 17800 nM
Beside the measured number, compound 4's estimate is 1.1-fold (0.05 log units) above it; low and high end bracket the measured number.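

The urea end now has a step of its own in this assay: 3-methoxyphenyl in place of 4-chlorophenyl on an amide-type nitrogen gives an at least 1.1-fold lower number from compound 2 to compound 4 (0.05 log units; that floor lies within the scatter). Among the compounds that share the core of compound 2, compound 4 is the first to return a number, 17800 nM, so this series can now be read at this position as a value. Going by these compounds, the step gives only a floor and its full size stays open, since its starting end is a limit and not a number: the limit of > 20000 nM in this assay, at which 2 of the 4 values shown sit.

The compounds shown leave open whether the methoxy group or the loss of the chlorine accounts for compound 4 returning a number, which a 4-methoxyphenyl or a 3-chlorophenyl group on the same amide-type nitrogen would help to separate. They also leave open how a cyclohexyl group or a phenyl ring carrying a carboxylic acid would read at this position in this assay.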